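Compound 4: Trifluoromethylphenyl in Place of Oxane

The compounds below may be only part of what the source reports. "The series", "measured", "known", "first", "only" and "open" are said of these compounds alone.

Compound 2 `Cc1noc(-c2nc(C)c3c(c2N)C(=O)N(CC2CCOCC2)C3=O)n1` is measured in a physicochemical assay for solubility, using the shake flask method, in simulated intestinal fluid, measured as kinetic solubility, with a stated time of 2 h, at 25 degrees C, at pH 6.5 (a higher number here means a more soluble compound, a lower number a less soluble compound), where compound 2 gives 5700 nM. Its nearest neighbour among the numbers shown is compound 3 `Cc1noc(-c2nc(C)c3c(c2N)C(=O)N(C(C)c2ccccc2)C3=O)n1`, which gives 10900 nM. The step of a 1.9-fold higher number from compound 2 to compound 3 (0.28 log units; within the scatter) came with 1-phenylethyl in place of (oxan-4-yl)methyl on an amide-type nitrogen in a ring. Compound 1 `Cc1nc(C(N)=O)c(N)c2c1C(=O)N(Cc1ccccc1)C2=O` returns only a limit of the assay, < 5000 nM. Compound 4 `Cc1noc(-c2nc(C)c3c(c2N)C(=O)N(Cc2ccccc2C(F)(F)F)C3=O)n1` is not yet measured; it differs from compound 2 by 2-(trifluoromethyl)phenyl in place of oxan-4-yl on a saturated chain carbon bound to an amide-type nitrogen in a ring. Going by the values given here, the one measured step that bears on this change, where 1-phenylethyl replaced (oxan-4-yl)methyl, stayed within the scatter, so the step for compound 4 is expected and estimated as a 1.4-fold lower number from compound 2 to compound 4 (0.15 log units; within the scatter), again within the scatter. Compound 4 is estimated at 4000 nM, between 1500 nM and 10000 nM, and given the limit of < 5000 nM in this assay, at which 1 of the 3 values shown sits, the result may again be only a limit.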

Compound 4, solubility: < 5000 nM
Compound 4 was reported as a limit; the forecaster's own chance of this, stated with the estimate: 40%; the middle value lies beyond the limit too.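

Compound 4 returns only a limit of the assay, < 5000 nM. Read as an at least 1.1-fold lower number from compound 2 to compound 4 (0.05 log units; that floor lies within the scatter), the change to 2-(trifluoromethyl)phenyl gives only a floor, so its true size stays unknown. Unlike the step to compound 3, this change on a saturated chain carbon bound to an amide-type nitrogen in a ring ends at the limit: the limit of < 5000 nM in this assay, at which 2 of the 4 values shown sit.

On these data alone, whether an amine or a carboxylic acid in place of oxan-4-yl would give a number clear of that limit in this assay stays open. So does the reading of a plain phenyl at this place on the core of compound 2.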